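Removing One Hydroxyl: What to Expect for Compound 4

This account rests on a few compounds, and the source may have more. Where it says the series, first, only, none or still open, it means among the compounds named here.

Of the compounds shown here, three sharing one core have been tested in an assay on HEK293 cells for inhibition of protein kinase C zeta type (Homo sapiens), read by 33P incorporation, with a stated time of 40 min, tested at 20 uM, in the presence of a further agent that is not named here; a higher number here means more inhibition at the concentration tested (going by the name of the read-out), a lower number less inhibition. Compound 1 `COc1ccc(C2=NN(c3ccc(Cl)cc3)C(c3ccc(Cl)cc3)C2)cc1` gives 23%. Compound 2 `COc1cccc(C2=NN(c3ccc(Cl)cc3)C(c3ccc(Cl)cc3)C2)c1` gives 17.9%. Compound 3 `Oc1ccc(C2=NN(c3ccc(Cl)cc3)C(c3ccc(Cl)cc3)C2)c(O)c1` gives 71.1%, the highest of the three; the steps of a number 48.1 percentage points higher from compound 1 to compound 3 (beyond the scatter) and a number 53.2 percentage points higher from compound 2 to compound 3 (beyond the scatter) are both large and beyond the scatter, whereas the step of a number 5.1 percentage points lower from compound 1 to compound 2 (within the scatter) lies within it.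

Compound 4 `Oc1cccc(C2=NN(c3ccc(Cl)cc3)C(c3ccc(Cl)cc3)C2)c1` has not yet been measured. It differs from compound 3 in one place: 3-hydroxyphenyl in place of 2,4-dihydroxyphenyl on a carbon with a double bond to nitrogen. Among the compounds with values here, no measured pair swaps a single hydroxyl for a single methoxy group, so the step to compound 4 cannot be read off directly. The two large steps into compound 3 show how much the number rose when a single methoxy group gave way to the 2,4-dihydroxyphenyl ring; compound 4 keeps only one hydroxyl, and compound 2, which bears a 3-methoxyphenyl group in the same place, gives a low number. A drop is therefore expected, a number 36.1 percentage points lower from compound 3 to compound 4 (beyond the scatter), beyond the scatter but probably not all the way back to the level of compound 2. Compound 4 is estimated at 35%, with a range from 15% to 55%.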

Compound 4, a percentage reported as inhibition, at one concentration (the size of the read-out at that concentration, not a potency): 69.3%
Estimate against measurement, compound 4: 34.3 percentage points below; measured number above the stated range.
By their numbers in this assay, from the lowest: compounds 2 and 1 (each within the scatter of the next); then compounds 4 and 3 (each within the scatter of the next).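

In this assay the step of a number 1.8 percentage points lower from compound 3 to compound 4 (within the scatter) shows that this position does not need the 2,4-dihydroxyphenyl ring, since the 3-hydroxyphenyl group alone keeps the number in the same range. The comparison with compound 2 is the cleanest so far. Only hydrogen in place of methyl on an oxygen on an aromatic ring separates the two compounds, and that single change gives a number 51.4 percentage points higher from compound 2 to compound 4 (beyond the scatter) in this pair, while the step of a number 46.3 percentage points higher from compound 1 to compound 4 (beyond the scatter) points the same way although the group is also a 4-methoxyphenyl rather than a 3-substituted ring at the start. So among these compounds the large rise goes with a free hydroxyl in place of a methoxy group, not with having two hydroxyl groups on the ring, and nothing available here explains why this single methyl makes such a difference.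

The compounds shown leave open how a plain phenyl ring, a 4-hydroxyphenyl group or a 2-hydroxyphenyl group would compare at this position, so it remains unclear whether the hydroxyl must sit where compound 4 has it. They also leave open whether an amine or a carboxylic acid could take the place of the hydroxyl, and how compound 3 and compound 4 compare in potency, as each number comes from a single concentration.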